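A few compounds are considered here, and "the series" means these few. Any claim that something is new, unique, unknown or untested is made for them only; others in the source may bear on it.

Working notes on the series, read in a physicochemical assay for solubility, read by HPLC, using the shake flask method, in phosphate buffer, with a stated time of 20 h, at pH 6.5; on this read-out higher numbers stand for higher solubility and lower numbers for lower solubility. Compound 1 (`CN1CCN(CC2CCN(c3nccc4[nH]c(-c5ccc(F)c(F)c5)nc34)CC2)CC1`) gives 195000 nM and compound 2 (`CN1CCN(C2CCN(c3nccc4[nH]c(-c5cccc(OC(F)(F)F)c5)nc34)CC2)CC1`) gives 190000 nM in this set, while compound 3 (`CN1CCN(CC2CCN(c3nccc4[nH]c(-c5cccc(OC(F)(F)F)c5)nc34)CC2)CC1`) gives 200000 nM and stands level with both, all three values lying within the scatter of one another. Compound 4 (`CN1CCN(CC2CCN(c3nccc4[nH]c(-c5ccc(F)c(Cl)c5)nc34)CC2)CC1`) carries 3-chloro-4-fluorophenyl in place of 3-(trifluoromethoxy)phenyl on an aromatic carbon. Going by the values given here, the closest precedent is the exchange of 3,4-difluorophenyl for 3-(trifluoromethoxy)phenyl at that carbon, measured as a 1.0-fold higher number from compound 1 to compound 3 (0.01 log units; within the scatter) and so without a visible effect. The other measured step, a 1.1-fold higher number from compound 2 to compound 3 (0.02 log units; within the scatter), concerns the (4-methylpiperazin-1-yl)methyl group and bears on this change only indirectly. Compound 4 differs from compound 1 by a group not yet tested, so some uncertainty remains. The step expected is therefore small (a 1.1-fold lower number from compound 3 to compound 4 (0.03 log units; within the scatter)), with no move beyond the scatter anticipated. For compound 4 the estimated value is 185000 nM, with an expected range of 105000 nM to 215000 nM.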

Compound 4, solubility: 155000 nM
The estimate for compound 4 lay 1.2-fold (0.08 log units) above the measured number; low and high end bracket the measured number.
By their numbers in this assay, from the lowest: compounds 4, 2, 1 and 3 (each within the scatter of the next).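

In this assay, the exchange of 3-(trifluoromethoxy)phenyl for 3-chloro-4-fluorophenyl on the aromatic carbon between two ring nitrogen atoms leaves the number within the scatter (a 1.3-fold lower number from compound 3 to compound 4 (0.11 log units; within the scatter)). The smaller exchange of chloro for fluoro on the aryl ring also stays within the scatter (a 1.3-fold lower number from compound 1 to compound 4 (0.10 log units; within the scatter)), so the three aryl groups carried by compound 1, compound 3 and compound 4 are not told apart at this position by this read-out. No supporting measurement is available to account for this absence of a visible step.

On these data alone, whether an aryl group bearing a carboxylic acid or an amine at this carbon would produce a step beyond the scatter remains open. Also open, as far as these compounds go, is whether replacing the aryl group with a longer alkyl chain would do so.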